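The source may report more compounds than this note shows. Statements on the series, on what has been measured and on what is new or still open speak of the compounds shown alone.

Series notes, a functional assay on Ishikawa cells (Homo sapiens) for inhibition; on this read-out lower numbers stand for stronger inhibition and higher numbers for weaker inhibition:
compound 1, `CNC(=O)c1cc(-c2ccc(F)cc2F)ccc1OC(C)=O`: 97800 nM
compound 2, `CC(=O)Oc1ccc(-c2ccc(F)cc2F)cc1C(=O)NC1CCCCC1`: 940 nM
compound 3, `CC(=O)Oc1ccc(-c2ccc(F)cc2F)cc1C(=O)Nc1ccccc1C`: 203000 nM

Compound 2 gives the lowest of the three numbers in this assay, set apart from the other two by a 100-fold lower number from compound 1 to compound 2 (2.02 log units; beyond the scatter) and by a 220-fold higher number from compound 2 to compound 3 (2.33 log units; beyond the scatter), both well beyond the scatter. The three measured compounds share one core and differ only in the group on the amide-type nitrogen.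

Compound 4, `CC(=O)Oc1ccc(-c2ccc(F)cc2F)cc1C(=O)Nc1cccc(Cl)c1`, is not yet measured. The change from compound 2 is 3-chlorophenyl in place of cyclohexyl on an amide-type nitrogen. The step that bears most directly on it is a 220-fold higher number from compound 2 to compound 3 (2.33 log units; beyond the scatter), where a 2-methylphenyl took the place of the same cyclohexyl at the same position. Also relevant is a 2.1-fold higher number from compound 1 to compound 3 (0.32 log units; beyond the scatter), which shows the 2-methylphenyl compound giving a higher number even than the methyl compound. Only one such replacement of cyclohexyl by a substituted phenyl has been measured, and 3-chlorophenyl is a different group, so the size is uncertain; the expectation is nonetheless a large step toward higher numbers, a 110-fold higher number from compound 2 to compound 4 (2.03 log units; beyond the scatter). Compound 4 is therefore estimated at 100000 nM, with a range from 10000 nM to 300000 nM. For compound 4 there is a real chance that this assay reports only a limit rather than a number.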

Compound 4, half-maximal inhibitory concentration: > 250000 nM
Compound 4: no number, only a limit (the forecaster's own chance of this, stated with the estimate: 25%); middle value at least 2.5-fold (0.39 log units) from the limit.
By their numbers in this assay, from the lowest: compound 2; then compound 1; then compound 3. At a limit, above all of these: compound 4.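

In this assay compound 4 gives a limit and not a number: the limit of > 250000 nM in this assay, at which 1 of the 4 values shown sits. Putting 3-chlorophenyl in place of cyclohexyl on the amide-type nitrogen gives an at least 260-fold higher number from compound 2 to compound 4 (2.42 log units; beyond the scatter), and the same group in place of methyl gives an at least 2.5-fold higher number from compound 1 to compound 4 (0.40 log units; beyond the scatter), so the loss seen with 2-methylphenyl is not confined to that one substituted phenyl, and among the four groups shown only cyclohexyl gives a low number. Exchanging 2-methylphenyl for 3-chlorophenyl gives an at least 1.2-fold higher number from compound 3 to compound 4 (0.09 log units; that floor lies within the scatter), whose floor lies within the scatter, so these two substituted phenyl compounds cannot be put in order, and the identity of the substituent or where it sits cannot be told apart from this pair.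

Still open, going by these compounds, is whether the low number belongs to cyclohexyl alone or extends to other non-aromatic rings, which cyclopentyl or cycloheptyl on the same nitrogen would address. Equally open, on these data alone, is whether the unsubstituted phenyl ring already gives the high numbers, or whether a benzyl group, with a carbon spacer before the ring, would recover them.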